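Three Measured Analogues and One Expected Cytotoxicity Value

The source may report more compounds than this note shows. Statements on the series, on what has been measured and on what is new or still open speak of the compounds shown alone.

Compound 1, `Fc1ccc(/C=C/c2nnc(-c3ccc4c(c3)OCCO4)o2)cc1`: 325000 nM
Compound 2, `COc1ccc(/C=C/c2nnc(-c3ccc4c(c3)OCCO4)o2)cc1`: 312000 nM
Compound 3, `O=[N+]([O-])c1ccc(/C=C/c2nnc(-c3ccc4c(c3)OCCO4)o2)cc1`: 299000 nM

All three numbers come from an ADME assay on HUVEC cells (Homo sapiens) for cytotoxicity, read by MTT assay, with a stated time of 24 h; a lower number here means that less compound is tolerated, a higher number that more compound is tolerated. Compound 2 sits between its two neighbours, but a 1.0-fold lower number from compound 1 to compound 2 (0.02 log units; within the scatter) and a 1.0-fold lower number from compound 2 to compound 3 (0.02 log units; within the scatter) show that nothing separates the three beyond the scatter; a 1.1-fold lower number from compound 1 to compound 3 (0.04 log units; within the scatter) says the same of the outer pair. The change to compound 4, `Cc1ccccc1/C=C/c1nnc(-c2ccc3c(c2)OCCO3)o1`, is 2-methylphenyl in place of 4-methoxyphenyl on a double-bonded chain carbon bound to a double-bonded chain carbon. The measured steps each exchanged one group on an aromatic carbon and all stayed within the scatter; none exchanged the whole ring, so they bear only loosely on this change. Compound 4 is therefore expected to show a 1.0-fold lower number from compound 2 to compound 4 (0.00 log units; within the scatter). The estimate for compound 4 is 310000 nM, with a range from 150000 nM to 620000 nM.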

Compound 4, half-maximal cytotoxic concentration: 356000 nM
Beside the measured number, compound 4's estimate is 1.1-fold (0.06 log units) below it, within the range that was stated.
By their numbers in this assay, from the lowest: compounds 3, 2, 1 and 4 (each within the scatter of the next).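

Even with the whole ring exchanged at this place, this assay shows a 1.1-fold higher number from compound 2 to compound 4 (0.06 log units; within the scatter) and a 1.1-fold higher number from compound 1 to compound 4 (0.04 log units; within the scatter) for 2-methylphenyl in place of 4-methoxyphenyl and 4-fluorophenyl. Among these compounds, then, exchanging the entire aromatic group on the double-bonded chain carbon, and not just one group on an aromatic carbon, stays within the scatter. Nothing available here gives a reason for this result. The compounds shown leave open whether a phenyl ring carrying an amine or a carboxylic acid, or a longer chain in place of the ring, would move the number beyond the scatter.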